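Methoxy in place of bromo on the aromatic ring

The source may report more compounds than this note shows. Statements on the series, on what has been measured and on what is new or still open speak of the compounds shown alone.

Compound 3 `O=C(/N=C/c1ccc(Br)cc1)Nc1ccc2c(c1)C(=O)C(=O)N2CN1CCCCC1` has been measured in a functional assay on the whole organism (strain Swiss albino) with Mus musculus as the target, with a stated time of 4 h (on this read-out higher numbers stand for an effect only at larger amounts of compound and lower numbers for an effect already at smaller amounts), and gives 300 mg/kg. For the measured compounds named here, that number stands level with compound 1 `O=C(/N=C/c1ccc(Cl)cc1)Nc1ccc2c(c1)C(=O)C(=O)N2CN1CCCCC1`, which gives 300 mg/kg, the two together being the highest of the three numbers so far; the step of no change at the digits printed from compound 1 to compound 3 (within the scatter) is within the scatter. Compound 2 `O=C(/N=C/c1ccc([N+](=O)[O-])cc1)Nc1ccc2c(c1)C(=O)C(=O)N2CN1CCCCC1` gives 100 mg/kg, and the step of a 3.0-fold lower number from compound 1 to compound 2 (0.48 log units; beyond the scatter) is the only one beyond the scatter, which read the other way is a 3.0-fold higher number from compound 2 to compound 3 (0.48 log units; beyond the scatter).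

The next compound, compound 4 `COc1ccc(/C=N/C(=O)Nc2ccc3c(c2)C(=O)C(=O)N3CN2CCCCC2)cc1`, differs from compound 3 by methoxy in place of bromo on an aromatic carbon. Going by the values given here, none of the measured steps involves a methoxy group: the two kinds of change seen so far swap one halogen for another, or a halogen for nitro. The halogen swap left the number unchanged, and only nitro moved it, modestly. Methoxy is neither of these, so there is no measured precedent pointing in either direction, and the plainest reading is a step no larger than the scatter.

Compound 4 is therefore expected to give 300 mg/kg, within 100 mg/kg to 600 mg/kg. The step of no change at the digits printed from compound 3 to compound 4 (within the scatter) is estimated to stay within the scatter.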

Compound 4, minimum effective dose: 300 mg/kg
Beside the measured number, compound 4's estimate shows no gap at the digits printed; the measured number falls inside the stated range.
By their numbers in this assay, from the lowest: compound 2; then compounds 1, 3 and 4 (each within the scatter of the next).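

In this assay the first non-halogen group other than nitro joins the halogen level, with no change at the digits printed from compound 3 to compound 4 (within the scatter) and no change at the digits printed from compound 1 to compound 4 (within the scatter) on the same aromatic carbon, so 4-bromophenyl to 4-methoxyphenyl brings no readable step even though methoxy has two heavy atoms and a hydrogen-bond acceptor where bromo has one heavy atom and none. For the compounds shown here, the level at this place is therefore not confined to halogens, and a 3.0-fold higher number from compound 2 to compound 4 (0.48 log units; beyond the scatter) in this series leaves nitro, in compound 2, as the only one of the four groups set apart beyond the scatter. No measurement in hand bears on what sets nitro apart from chloro, bromo and methoxy.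

Still open, on these data alone, is whether an amine, a carboxylic acid or a longer chain such as ethoxy at this place would stay at the level of compounds 1, 3 and 4 or fall with compound 2. Also open, as far as these compounds go, is whether the same ranking of these groups would hold with a change elsewhere on the shared core.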